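Methyl on the Aminopyrimidine: Expected Cytotoxicity of Compound 4

The source may report more compounds than this note shows. Statements on the series, on what has been measured and on what is new or still open speak of the compounds shown alone.

Measured so far:
- compound 1, `CC(C)=CCOc1cccc(Nc2nccs2)c1`: 23000 nM
- compound 2, `CC(C)=CCOc1cc(Nc2nccs2)ccc1C`: 17000 nM
- compound 3, `CC(C)=CCOc1cc(Nc2nccc(N)n2)ccc1Cl`: 500 nM

In a functional assay on MT2 cells (Homo sapiens) for cytotoxicity, read by MTT assay (on this read-out lower numbers stand for higher toxicity in this test and higher numbers for lower toxicity in this test), compound 1 gives 23000 nM and compound 2 gives 17000 nM. The two differ by methyl in place of hydrogen on an aromatic carbon, and the step of a 1.4-fold lower number from compound 1 to compound 2 (0.13 log units; within the scatter) is small. Compound 3, in the same test, gives 500 nM; how its core differs from that of compound 1 is not broken down here, beyond the fact that compound 3 stands well apart from both compound 1 and compound 2.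

Compound 4, `CC(C)=CCOc1cc(Nc2nc(C)cc(N)n2)ccc1Cl`, has not yet been tested. It differs from compound 3 by methyl in place of hydrogen on an aromatic carbon. This is the same kind of change as that from compound 1 to compound 2, not the same one: there the methyl entered a six-membered aromatic ring of carbon only, ortho to a (3-methylbut-2-en-1-yl)oxy group and para to a (1,3-thiazol-2-yl)amino group, whereas here it enters a six-membered aromatic ring with 2 nitrogen, next to the ring nitrogen and meta to an amino group.

Because a 1.4-fold lower number from compound 1 to compound 2 (0.13 log units; within the scatter) stayed within the scatter, a similarly small step is expected here, a 1.3-fold lower number from compound 3 to compound 4 (0.10 log units; within the scatter). Compound 4 is therefore estimated at 400 nM in this assay, between 200 nM and 1000 nM.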

Compound 4, half-maximal cytotoxic concentration: < 4 nM
Compound 4: only a limit was reported (the forecaster's own chance of this, stated with the estimate: 5%); middle value at least 100-fold (2.00 log units) away from the limit.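

In this assay, going by these compounds, methyl in place of hydrogen on an aromatic carbon gives an at least 120-fold lower number from compound 3 to compound 4 (2.09 log units; beyond the scatter), so the same change does not behave alike on the two cores: the same change on two cores in this assay, a 1.4-fold lower number (0.13 log units; within the scatter) from compound 1 to compound 2 and an at least 120-fold lower number (2.09 log units; beyond the scatter) from compound 3 to compound 4, at least 92-fold (1.96 log units) apart, beyond the scatter of two such steps Compound 4 stands at < 4 nM, which is a limit of the assay and not a number, so the full size of this step stays unknown. The result on one core therefore did not carry over to the other, but the comparison does not show what sets them apart: the methyl enters a different ring in each pair, and compound 1 and compound 3 differ in more than one place.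

The compounds shown leave open whether only methyl gives this large step, or whether an ethyl group, a methoxy group or a fluorine on the same carbon would do the same. They also leave open whether a third core would follow the small step or the large one.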